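Swapping chloro for methoxy on an aromatic ring

This account rests on a few compounds, and the source may have more. Where it says the series, first, only, none or still open, it means among the compounds named here.

For the measured compounds named here, only two compounds have so far been measured in a functional assay on U-251 cells (Homo sapiens) for inhibition, read by sulforhodamine B assay, with a stated time of 48 h (a lower number here means a stronger inhibitor of growth, a higher number a weaker inhibitor of growth), and they share most of their structure. There, compound 1 (`S=C(N/N=C/c1cccs1)Nc1ccc(Cl)cc1`) gives 8300 nM and compound 2 (`S=C(N/N=C/c1cccs1)Nc1cccc2ccccc12`) gives 12700 nM as its value. Going by the values given here, these two numbers lie within the usual scatter of each other, so compound 1 stands level with the only other measured compound.

Compound 3 (`COc1ccc(NC(=S)N/N=C/c2cccs2)cc1`) keeps the core of compound 1 and changes one group: methoxy in place of chloro on an aromatic carbon, para to a large group (methoxy in place of chloro on an aromatic carbon). Among the compounds with values here, no two measured compounds differ in just one place, so the data give no direct guide to the size of this swap. Even so, compound 2 (12700 nM) stays within the scatter of compound 1 (8300 nM) despite a different aromatic group, which suggests a modest change here. The expected result is no shift beyond the scatter, with a slight lean towards weaker inhibition (a 1.3-fold higher number from compound 1 to compound 3 (0.12 log units; within the scatter)). In this assay compound 3 is estimated at 11000 nM (expected range 5000 nM to 25000 nM).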

Compound 3, concentration for 50% growth inhibition: > 100000 nM
Compound 3: only a limit was reported; the forecaster's own chance of this, stated with the estimate: 8%; at least 9.0-fold (0.95 log units) between middle value and limit.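

In this assay, methoxy in place of chloro on an aromatic carbon, para to a large group, gives an at least 12-fold higher number from compound 1 to compound 3 (1.08 log units; beyond the scatter). For the compounds shown here, this is the first step that changes only one place, and it shows that this position is far from indifferent to what sits on it: exchanging one small group for another is enough to produce a step well beyond the scatter. For compound 3 the reported result is a limit and not a number, so the true size of the step remains unknown and only its lower bound can be read: the limit of > 100000 nM in this assay, at which 1 of the 3 values shown sits.

The compounds shown leave open whether the chloro group of compound 1 is unusually favourable here or the methoxy group of compound 3 is unusually unfavourable, a question that a fluoro, methyl or hydroxy group at this same position could help to settle. They also leave open whether the same swap would produce a step of similar size on another carbon of the ring, or in a compound with a different core.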